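The source may report more compounds than this note shows. Statements on the series, on what has been measured and on what is new or still open speak of the compounds shown alone.

Among the measured compounds shown here, in a functional assay on CHO cells for agonist activity at 5-hydroxytryptamine receptor 4 (Homo sapiens), read by a luciferase reporter and cAMP accumulation, with a stated time of 4 h (a higher number here means that more compound is needed for the effect, a lower number that less compound is needed), three compounds have numbers so far. Compound 1 `CCN1CCC(NC(=O)c2nc(C(C)C)n3ccccc23)CC1` gives 50 nM in this assay. Compound 3 `CC(C)c1nc(C(=O)NC[C@@H]2[C@H]3CN(C4CCOCC4)C[C@@H]23)c2ccccn12` gives 20.7 nM in this assay, the lowest of the two numbers, and its step to compound 1 lies beyond the usual scatter. Compound 2 `CC(C)c1nc(C(=O)NC2C3CN(CC(C)(C)O)CC32)c2ccccn12` returns only a limit in this assay, > 10000 nM, not a number. the limit of > 10000 nM in this assay, at which 1 of the 3 values shown sits, marks where that value sits.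

Compound 4 `COCC(C)(C)CN1C[C@@H]2[C@@H](CNC(=O)c3nc(C(C)C)n4ccccc34)[C@@H]2C1` has not yet been measured in this assay. It differs from compound 3 in one place: 2-(methoxymethyl)-2-methylpropyl in place of oxan-4-yl on an amine nitrogen in a ring. For the measured compounds named here, no measured pair shows a change of this kind on that amine nitrogen, so the numbers at hand give no direct guide to its size. Compound 3 serves as the anchor, and the step from it is expected to be modest and toward a higher number: a 2.2-fold higher number from compound 3 to compound 4 (0.34 log units; beyond the scatter). The estimate for compound 4 in this assay is 45 nM, with a range expected from 10 nM to 200 nM.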

Compound 4, half-maximal effective concentration: 19.8 nM
For compound 4 the middle estimate is 2.3-fold (0.36 log units) above the measured one; the measured number falls inside the stated range.
By their numbers in this assay, from the lowest: compounds 4 and 3 (each within the scatter of the next); then compound 1. At a limit, above all of these: compound 2.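

The exchange of oxan-4-yl for 2-(methoxymethyl)-2-methylpropyl on the amine nitrogen in a ring gives a 1.0-fold lower number from compound 3 to compound 4 (0.02 log units; within the scatter) in this assay. Among the compounds shown here, this is the first measured pair that differs at this nitrogen, and it shows that a substituent with no ring can stand in place of the six-membered non-aromatic ring without a change beyond the usual scatter. No measurement at hand accounts for this outcome.

Going by these compounds, what remains open is whether the oxygen shared by the two groups matters, since a plain hydrocarbon chain such as butyl on this nitrogen would be needed to tell. On these data alone, how far the substituent can vary also remains open, for instance with a carboxylic acid or a further amine at its end.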